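Swapping a Thiophene for Hydroxyphenyl on a Pyridine Core

The compounds below may be only part of what the source reports. "The series", "measured", "known", "first", "only" and "open" are said of these compounds alone.

Measured so far in a functional assay on HL-60 cells (Homo sapiens) for cytotoxicity, read by ELISA, with a stated time of 2 days; a lower number here means a stronger inhibitor, a higher number a weaker inhibitor:
- Compound 1, `Oc1ccccc1-c1cc(-c2ccccc2)cc(-c2ccccc2O)n1`: 22400 nM
- Compound 2, `Oc1cccc(-c2cc(-c3ccccc3)cc(-c3ccsc3)n2)c1`: 10300 nM
- Compound 3, `Oc1cccc(-c2cc(-c3ccccc3)cc(-c3ccncc3)n2)c1`: 23900 nM

Compound 2 gives the lowest number of the three in this assay, so it is the strongest inhibitor shown. For the measured compounds named here, its nearest neighbour is compound 1, whose number is higher, and the furthest is compound 3, reached by the one single-point step on record: a 2.3-fold higher number from compound 2 to compound 3 (0.37 log units; beyond the scatter). That step sits at the same place on the shared core that is changed here.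

The new compound, compound 4, `Oc1cccc(-c2cc(-c3ccccc3)cc(-c3cccc(O)c3)n2)c1`, differs from compound 2 as follows: 3-hydroxyphenyl in place of thiophen-3-yl on an aromatic carbon. The thiophen-3-yl of compound 2 gives way to a 3-hydroxyphenyl, so compound 4 carries two such groups on its core.

Going by the values given here, only the step from compound 2 to compound 3 bears directly on this change, and there a six-membered aromatic ring in place of the thiophen-3-yl produced a modest rise in the number. Compound 1, which also carries two hydroxyphenyl groups, sits above compound 2 as well. A modest rise is therefore expected for compound 4: a 1.9-fold higher number from compound 2 to compound 4 (0.29 log units; within the scatter). Compound 4 is estimated at 20000 nM, within a range from 8000 nM to 50000 nM.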

Compound 4, half-maximal inhibitory concentration: 16400 nM
Compound 4: the middle estimate sits 1.2-fold (0.09 log units) above what was measured; measured number inside the range.
By their numbers in this assay, from the lowest: compounds 2, 4, 1 and 3 (each within the scatter of the next, the first and the last beyond it).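

In this assay the 3-hydroxyphenyl in place of thiophen-3-yl gives one step (a 1.6-fold higher number from compound 2 to compound 4 (0.20 log units; within the scatter)), and the 3-hydroxyphenyl in place of pyridin-4-yl gives another (a 1.5-fold lower number from compound 3 to compound 4 (0.16 log units; within the scatter)). At this place on the shared core, the 3-hydroxyphenyl therefore cannot be told apart from either earlier group, although those two groups do separate from each other (a 2.3-fold higher number from compound 2 to compound 3 (0.37 log units; beyond the scatter)); it also brings a hydrogen-bond donor that the thiophen-3-yl lacks, and the two numbers still stay within the scatter. Nothing available explains why these three groups give such closely spaced numbers.

As far as these compounds go, all three groups compared at this position are aromatic rings, so it remains open whether an amine, a carboxylic acid or a longer alkyl chain in the same place would move the number further in either direction. From the compounds shown here alone, what the hydroxyl itself contributes also remains open, and a plain phenyl at this position, compared directly with compound 4, would address that question.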